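The source may report more compounds than this note shows. Statements on the series, on what has been measured and on what is new or still open speak of the compounds shown alone.

Compound 1 `C=C(C)CCOc1c(OC)cc(/C=C/CO)cc1OC` gives > 100000 nM in a functional assay on A549 cells (Homo sapiens) for cytotoxicity, read by MTT assay, with a stated time of 72 h; a higher number here means a weaker inhibitor, a lower number a stronger inhibitor.
Compound 2 `CC(C)=CCOc1ccc(C(=O)/C=C/c2ccc(O)cc2)c(O)c1` gives 66000 nM in this assay.
Compound 3 `COc1cc(/C=C/C(=O)O)ccc1OCC=C(C)C` gives > 100000 nM in this assay.

For compound 1 the value is a limit of the assay, not a number. Going by these compounds, compound 1 therefore sits at the limit of > 100000 nM in this assay, at which 2 of the 3 values shown sit, so its own cytotoxicity is unknown beyond that limit. Compound 3 likewise gives only a limit. Among the compounds with values here, compound 2 is the one compound with a measured number.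

Compound 4 `COc1cc(/C=C/CO)cc(OC)c1O` has not yet been measured. The change from compound 1 is hydrogen in place of 3-methylbut-3-en-1-yl on an oxygen on an aromatic ring; the (3-methylbut-3-en-1-yl)oxy group becomes a hydroxy group. The expected step that the limit leaves unreadable from compound 1 to compound 4 is none beyond the scatter, since compound 1 shows only a limit and no measured step among these compounds points elsewhere. Compound 4 is expected to give about 150000 nM, within 40000 nM to 600000 nM.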

Compound 4, half-maximal inhibitory concentration: > 100000 nM
Compound 4: no number, only a limit (the forecaster's own chance of this, stated with the estimate: 80%); the middle value does not contradict the limit.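

Within the data shown here, compound 1 and compound 4 both give only a limit, not a number, so no step between them can be read: the limit of > 100000 nM in this assay, at which 3 of the 4 values shown sit. The compounds shown leave open whether replacing (3-methylbut-3-en-1-yl)oxy with hydroxy changes cytotoxicity at all.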